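The source may hold more compounds than are shown below. What is called first, only, known or untested is meant among the compounds shown, and "the series" means these compounds.

Of the compounds shown here, two have so far been tested in a functional assay on the whole organism for agonist activity, with Rattus norvegicus as the target; a higher number here means that more compound is needed for the effect, a lower number that less compound is needed. Compound 1 `C1=C(CCN2CCN(c3cccc4c3OCCO4)CC2)c2ccccc2C1` gives in this assay > 2.5 mg/kg, and that entry is a limit of the assay rather than a number; (the limit of > 2.5 mg/kg in this assay, at which 1 of the 2 values shown sits). Compound 2 `Clc1cccc2c1CC2CN1CCN(c2cccc3c2OCCO3)CC1` gives in this assay 40 mg/kg. Among the compounds with values here, compound 2 thus holds the only numerical reading so far, the remaining entry being a limit.

Compound 3 `c1ccc2c(c1)CC2CN1CCN(c2cccc3c2OCCO3)CC1` has not yet been measured. It differs from compound 2 in one place: hydrogen in place of chloro on an aromatic carbon. Within the data shown here, no step between two measured compounds carries this kind of change, so the two measured compounds give no guide to how removing the chloro moves the reading. Either direction remains open, and a change that stays within the scatter is as plausible as any other.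

The estimate for compound 3 therefore stays close to the reading of compound 2 and is given a wide range. Compound 3 is expected to give about 40 mg/kg in this assay, with a likely span from 10 mg/kg to 150 mg/kg. The expected step is no change at the digits printed from compound 2 to compound 3 (within the scatter), which is no movement beyond the usual scatter.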

Compound 3, minimum effective dose: 10 mg/kg
For compound 3 the middle estimate is 4.0-fold (0.60 log units) above the measured one; the measured number falls inside the stated range.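

In this assay, putting hydrogen in place of chloro on this aromatic carbon, ortho to a fused ring and meta to a fused ring, gives a 4.0-fold lower number from compound 2 to compound 3 (0.60 log units; beyond the scatter), so a change at this position can move the reading by more than the usual scatter. Since a lower number means that less compound is needed for the effect, this pair shows that the chloro is not required for activity in the whole animal and that, on this core, the compound without it needs the smaller dose. Within the data shown here, nothing measured so far accounts for this difference between the two compounds.

Hydrogen and chloro are the only two groups compared at this position, so it remains open whether fluoro, methyl, methoxy or a nitrile there would give a number nearer to that of compound 2 or to that of compound 3. This is also a single pair on a single core, so it cannot yet be said whether removing a chloro would have the same effect on any other core in the series, including that of compound 1, whose entry is a limit and not a number.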